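Sulfonyl aryl exchange on the proline amide series

The source may report more compounds than this note shows. Statements on the series, on what has been measured and on what is new or still open speak of the compounds shown alone.

The three measured compounds share one core and differ only in the group on the sulfonyl sulfur or on a saturated ring carbon. In a functional assay on the whole organism for inhibition, with Rattus norvegicus as the target, read by paw edema, with a stated time of 1 h, at a dose of 100 mg/kg by the oral route (a lower number here means less inhibition, a higher number more inhibition at the dose given (going by the name of the read-out)), compound 1 `Cc1ccccc1S(=O)(=O)N1CC(O)C[C@H]1C(=O)Nc1ccc(C(=O)O)cc1` gives 21.2%, compound 2 `Cc1ccc(S(=O)(=O)N2CC(O)C[C@H]2C(=O)Nc2ccc(C(=O)O)cc2)cc1` gives 60%, and compound 3 `Cc1ccccc1S(=O)(=O)N1CCC[C@H]1C(=O)Nc1ccc(C(=O)O)cc1` gives 39.4%. Compound 3 thus stands second of the three, beyond the scatter from both neighbours: a number 18.2 percentage points higher from compound 1 to compound 3 (beyond the scatter), while compound 2 lies higher still. Compound 4 `O=C(O)c1ccc(NC(=O)[C@@H]2CCCN2S(=O)(=O)c2ccc([N+](=O)[O-])cc2)cc1` is not yet measured; it differs from compound 3 in one place, (4-nitrophenyl in place of 2-methylphenyl on a sulfonyl sulfur). Among the compounds with values here, only one measured step touches the group on the sulfonyl sulfur, and it was large: a number 38.8 percentage points higher from compound 1 to compound 2 (beyond the scatter). Within the data shown here, that step exchanged one methylphenyl for another; no measured compound carries a nitrophenyl, so its effect is untested. On this basis an upward step is expected, a number 15.6 percentage points higher from compound 3 to compound 4 (beyond the scatter), though with wide uncertainty. Compound 4 is therefore estimated at 55% in this assay, within a range of 30% to 80%.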

Compound 4, a percentage reported as inhibition, in the whole organism at one dose (the size of the read-out at that dose, not a potency): 45.9%
Compound 4: the middle estimate sits 9.1 percentage points above what was measured; measured number inside the range.
By their numbers in this assay, from the lowest: compound 1; then compounds 3 and 4 (each within the scatter of the next); then compound 2.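

At the sulfonyl sulfur, on the core without the hydroxy group, 4-nitrophenyl in place of 2-methylphenyl gives a number 6.5 percentage points higher from compound 3 to compound 4 (within the scatter) in this assay, so this exchange does not separate the two compounds. Replacing 2-methylphenyl therefore does not always produce a step beyond the scatter: with the hydroxy group present, 4-methylphenyl did, with a number 38.8 percentage points higher from compound 1 to compound 2 (beyond the scatter), whereas 4-nitrophenyl without that group does not. No measurement at hand accounts for the difference between these two steps.

As far as these compounds go, whether 4-methylphenyl would give a step of similar size on the core without the hydroxy group remains open. Also open, from the compounds shown here alone, is how an amine or a methoxy group in place of the nitro group on the phenyl ring would read in this assay at this position.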